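Hydrogen in place of bromo in compound 3

This account rests on a few compounds, and the source may have more. Where it says the series, first, only, none or still open, it means among the compounds named here.

In a functional assay on SiHa cells (Homo sapiens) for inhibition, read by CCK-8 assay, with a stated time of 72 h, tested at 10 uM (a lower number here means less inhibition of growth, a higher number more inhibition of growth at the concentration tested), compound 3 (`CN(C)C(=O)c1cc2cnc(Nc3ccc(NC(=O)C4(C(=O)Nc5ccc(Br)cc5)CC4)cc3)nc2n1C1CCCC1`) stands at 98.8% of growth inhibition. Compound 1 (`CN(C)C(=O)c1cc2cnc(Nc3ccc(NC(=O)C4(C(=O)Nc5ccc(F)cc5)CC4)cc3)nc2n1C1CCCC1`) reaches 98% in the same test, within the scatter of compound 3, whereas compound 2 (`CN(C)C(=O)c1cc2cnc(Nc3ccc(N)cn3)nc2n1C1CCCC1`) gives 61.5% there, a clearly lower number. Compound 4 (`CN(C)C(=O)c1cc2cnc(Nc3ccc(NC(=O)C4(C(=O)Nc5ccccc5)CC4)cc3)nc2n1C1CCCC1`) differs from compound 3 by a single change (hydrogen in place of bromo on an aromatic carbon), hydrogen in place of bromo on an aromatic carbon. Among the measured compounds shown here, the only measured step at this place, a number 0.8 percentage points higher from compound 1 to compound 3 (within the scatter) for bromo in place of fluoro, stays within the scatter, so no step beyond the scatter is expected in this assay here, although hydrogen at this place is untested. The estimated change is a number 3.8 percentage points lower from compound 3 to compound 4 (within the scatter) and would lie within the scatter. Compound 4 is therefore expected at 95% within an estimated range of 85% to 100% in this test.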

Compound 4, percent growth inhibition at one concentration: 106%
The estimate for compound 4 lay 11 percentage points below the measured number, outside the stated range (above it).
By their numbers in this assay, from the lowest: compound 2; then compounds 1, 3 and 4 (each within the scatter of the next).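

In this assay the halogen proves dispensable at this place, para to a large group: hydrogen in place of bromo gives a number 7.2 percentage points higher from compound 3 to compound 4 (within the scatter) and hydrogen in place of fluoro gives a number 8 percentage points higher from compound 1 to compound 4 (within the scatter) in the same test. The earlier step compared only two halogens, whereas the plain phenyl now shows that the number stays within the scatter with no halogen there at all. No measurement shown here accounts for this result.
The compounds shown leave open whether an amine or a carboxylic acid at this place would give a step beyond the scatter.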